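Swapping the chalcone aryl group toward a trimethoxyphenyl

The source may hold more compounds than are shown below. What is called first, only, known or untested is meant among the compounds shown, and "the series" means these compounds.

Compound 1 `COc1cc(/C=C/C(=O)c2cccc(-n3cc(-c4ccccc4)[nH]c3=O)c2)cc(OC)c1OC`: 480 nM
Compound 2 `COc1ccc(-c2cn(-c3cccc(C(=O)/C=C/c4ccc(O)c(OC)c4)c3)c(=O)[nH]2)cc1`: 2440 nM

Of the compounds shown here, two have been measured in a functional assay on LOX IMVI cells (Homo sapiens) for inhibition; a lower number here means a stronger inhibitor of growth, a higher number a weaker inhibitor of growth. Compound 1 gives 480 nM, while compound 2 gives 2440 nM, the higher of the two numbers; the gap between them lies beyond the usual scatter, so compound 2 is the weaker growth inhibitor of this pair. The two differ in two places at once, so no single step can be read from them.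

Compound 3 `COc1ccc(-c2cn(-c3cccc(C(=O)/C=C/c4cc(OC)c(OC)c(OC)c4)c3)c(=O)[nH]2)cc1` has not yet been measured. It differs from compound 2 in one place: 3,4,5-trimethoxyphenyl in place of 4-hydroxy-3-methoxyphenyl on a double-bonded chain carbon bound to a double-bonded chain carbon. The rest of the molecule is unchanged.

Compound 1 carries the same 3,4,5-trimethoxyphenyl group on its double-bonded chain carbon and gives 480 nM, which suggests that this group is compatible with the lower end of the numbers seen here. Compound 3 is therefore expected to show a lower number than compound 2 in this assay, the expected step being a 3.3-fold lower number from compound 2 to compound 3 (0.51 log units; beyond the scatter). The estimate for compound 3 is 750 nM, with a range from 250 nM to 2200 nM.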

Compound 3, concentration for 50% growth inhibition: 720 nM
Compound 3: middle estimate off by 1.0-fold (0.02 log units), on the high side; the measured number falls inside the stated range.
By their numbers in this assay, from the lowest: compounds 1 and 3 (each within the scatter of the next); then compound 2.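

In this assay, 3,4,5-trimethoxyphenyl in place of 4-hydroxy-3-methoxyphenyl on a double-bonded chain carbon bound to a double-bonded chain carbon gives a 3.4-fold lower number from compound 2 to compound 3 (0.53 log units; beyond the scatter), so this position clearly affects growth inhibition and this single change can be read directly, which the first pair did not allow. The other new comparison is a small one: methoxy in place of hydrogen on an aromatic carbon gives a 1.5-fold higher number from compound 1 to compound 3 (0.18 log units; within the scatter), so compounds 1 and 3 cannot be told apart, and with 3,4,5-trimethoxyphenyl in place this methoxy makes no measurable difference. Nothing available explains why the aryl change matters.

The entering group differs from the leaving one in two ways, with a methoxy where the hydroxy stood and one more methoxy on the ring, and the compounds shown cannot separate these two contributions. From the compounds shown here alone, it also remains open whether this position would tolerate a quite different group, such as a dimethoxyphenyl or an aminophenyl, and whether the methoxy step would stay as small with 4-hydroxy-3-methoxyphenyl in place.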